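Replacing a Saturated Chain with a Brominated Alkenyl Group

The source may report more compounds than this note shows. Statements on the series, on what has been measured and on what is new or still open speak of the compounds shown alone.

Measured so far:
- compound 1, `CCCCC(=O)N(Cc1ccc(OC)c(O)c1)c1cc(OC)c(OC)c(OC)c1`, 170 nM
- compound 2, `C/C=C/C(=O)N(Cc1ccc(OC)cc1)c1cc(OC)c(OC)c(OC)c1`, 500 nM

Both were tested in a functional assay on HCT-116 cells (Homo sapiens) for inhibition, read by MTT assay, with a stated time of 48 h; on this read-out lower numbers stand for stronger inhibition and higher numbers for weaker inhibition. Compound 1 gives the lower of the two numbers; compound 2 gives a higher number, and the gap between them lies beyond the usual scatter. The two compounds differ in more than one place, so no single change can be read from that gap.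

Compound 3, `COc1ccc(CN(C(=O)/C=C/CBr)c2cc(OC)c(OC)c(OC)c2)cc1O`, has not been measured. It is built from compound 1 by one change: 3-bromoprop-1-en-1-yl in place of butyl on a carbonyl carbon. For the measured compounds named here, nothing among the measured compounds shows this change on its own, so any guess must rest on the closeness of the two scaffolds.

The step of a 1.1-fold lower number from compound 1 to compound 3 (0.05 log units; within the scatter) is expected to be small, within the scatter. Compound 3 is expected to give about 150 nM, in the range from 50 nM to 500 nM.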

Compound 3, half-maximal inhibitory concentration: 59 nM
Compound 3: middle estimate off by 2.5-fold (0.41 log units), on the high side; measured number inside the range.
By their numbers in this assay, from the lowest: compound 3; then compound 1; then compound 2.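

In this assay, putting 3-bromoprop-1-en-1-yl in place of butyl on the carbonyl carbon gives a modest gain (a 2.9-fold lower number from compound 1 to compound 3 (0.46 log units; beyond the scatter)), the first single change seen at this position, and it shows that the number responds to what sits there. Both groups count the same number of heavy atoms and neither holds a ring, so the change lies in a bromine replacing a carbon and in a double bond outside aromatic rings, not in the heavy-atom count. Nothing measured here explains the step.

Whether the bromine, the double bond or both account for the step stays open; a 3-bromopropyl chain or a 3-chloroprop-1-en-1-yl group on the same carbonyl carbon would help separate them. On these data alone, how an amine at the end of the chain would read on the core of compound 1 is also open.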